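Swapping the Ring Group on the Oxygen of Compound 2

A few compounds are considered here, and "the series" means these few. Any claim that something is new, unique, unknown or untested is made for them only; others in the source may bear on it.

- compound 1 `COc1cc(C(C)O)ccc1OCCCN1CCC(C(c2ccc(F)cc2)c2ccc(F)cc2)CC1` gives 10 nM
- compound 2 `CC(=O)Nc1ccc(OCCCN2CCC(C(c3ccc(F)cc3)c3ccc(F)cc3)CC2)cc1` gives 12.6 nM

These two values come from a functional assay (aorta) with Oryctolagus cuniculus as the target (on this read-out lower numbers stand for tighter binding and higher numbers for weaker binding), and they cannot be told apart. For the measured compounds named here, the only measured step is a 1.3-fold higher number from compound 1 to compound 2 (0.10 log units; within the scatter), so compound 2 stands level with compound 1 on the numbers available.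

The next compound, compound 3 `COc1ccccc1OCCCN1CCC(C(c2ccc(F)cc2)c2ccc(F)cc2)CC1`, has not yet been measured. Reaching it from compound 2 puts 2-methoxyphenyl in place of 4-acetamidophenyl on an oxygen on a saturated carbon, while the rest of the molecule stays the same. The change in full is 2-methoxyphenyl in place of 4-acetamidophenyl on an oxygen on a saturated carbon.

The measured step bears on this change, as it also replaced only the group at that place on the oxygen. It gives a single precedent, and its size stayed within the scatter. No step beyond the scatter is therefore expected in this assay, in either direction, although one step is thin evidence and the range must stay wide. The estimated step is a 1.3-fold lower number from compound 2 to compound 3 (0.10 log units; within the scatter). For compound 3 the expected value is 10 nM, with an estimated range from 3 nM to 35 nM.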

Compound 3, dissociation constant: 2.51 nM
Estimate against measurement, compound 3: 4.0-fold (0.60 log units) above; measured number below the stated range.
By their numbers in this assay, from the lowest: compound 3; then compounds 1 and 2 (each within the scatter of the next).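

In this assay, the group on this oxygen now proves able to move the number: 2-methoxyphenyl in place of 4-acetamidophenyl gives a 5.0-fold lower number from compound 2 to compound 3 (0.70 log units; beyond the scatter), whereas the earlier swap at this place stayed within the scatter. The second new step isolates a smaller change, as hydrogen in place of 1-hydroxyethyl on an aromatic carbon gives a 4.0-fold lower number from compound 1 to compound 3 (0.60 log units; beyond the scatter), so the simpler 2-methoxyphenyl group binds more tightly here than the same ring carrying 1-hydroxyethyl. Compounds 1 and 2 have differently named groups and values that cannot be told apart, yet both carry a group at the 4 position of the ring and both stand above compound 3, though three compounds are too few to call this a rule, and nothing available explains the difference.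

What the methoxy group itself contributes stays open, as plain phenyl, with hydrogen in its place, is not among the compounds shown. Going by these compounds, it is also open whether an ethoxy group or a chlorine atom in place of the methoxy would keep the number this low, or whether a fluorine atom added to the ring of compound 3 would shift it in either direction.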